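Shifting the ethyl group on the anilide ring

The source may report more compounds than this note shows. Statements on the series, on what has been measured and on what is new or still open speak of the compounds shown alone.

Of the compounds shown here, two of a shared core have been measured in a functional assay on NCI-H1975 cells (Homo sapiens) for inhibition, read by MTT assay, with a stated time of 72 h; on this read-out higher numbers stand for weaker inhibition and lower numbers for stronger inhibition. Compound 1 `O=C(CSc1nc(Nc2ccccc2)c2ccccc2n1)Nc1cccc(Br)c1` gives 10100 nM. Compound 2 `CCc1cccc(NC(=O)CSc2nc(Nc3ccccc3)c3ccccc3n2)c1` gives 12000 nM. For the measured compounds named here, the one step between them, a 1.2-fold higher number from compound 1 to compound 2 (0.07 log units; within the scatter), is within the scatter, so the two numbers cannot be ordered, and compound 2 stands simply at the higher of the two numbers, with compound 1 as its nearest neighbour.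

Compound 3 `CCc1ccc(NC(=O)CSc2nc(Nc3ccccc3)c3ccccc3n2)cc1` has not been measured. It differs from compound 2 in that the two have the same atoms, joined differently: 4-ethylphenyl in place of 3-ethylphenyl on an amide-type nitrogen. Going by the values given here, no measured step bears on this change; the only step at hand, from compound 1 to compound 2, exchanged one group for another on the aromatic carbon rather than the point at which the ethylphenyl is joined, and it was within the scatter. With nothing pointing either way, compound 3 is expected to show a step of no change at the digits printed from compound 2 to compound 3 (within the scatter) in this assay, that is, none beyond the scatter. Compound 3 is therefore estimated at 12000 nM, within a range of 5000 nM to 30000 nM.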

Compound 3, half-maximal inhibitory concentration: 9910 nM
Compound 3: middle estimate off by 1.2-fold (0.08 log units), on the high side; the measured number falls inside the stated range.
By their numbers in this assay, from the lowest: compounds 3, 1 and 2 (each within the scatter of the next).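

For the compounds shown here, compound 2 and compound 3 are the first pair here to differ only in how the ethylphenyl is joined, and in this assay the change of 3-ethylphenyl to 4-ethylphenyl on the amide-type nitrogen gives a 1.2-fold lower number from compound 2 to compound 3 (0.08 log units; within the scatter). This adds a change of attachment to the earlier change of group, and neither moves the number beyond the scatter. The step of a 1.0-fold lower number from compound 1 to compound 3 (0.01 log units; within the scatter) is also within the scatter, so the three compounds cannot be ordered, and the shown changes on this ring leave the number where it was; nothing at hand gives a reason for this result.

As far as these compounds go, all three compounds carry a bromo or ethyl group on this ring, so it remains open whether a carboxylic acid, an amine or a longer chain such as hexyl in the same place would move the number beyond the scatter. From the compounds shown here alone, it also remains open whether a change elsewhere on the shared core, rather than on the anilide ring, would shift the number in this assay at all.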